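The compounds below may be only part of what the source reports. "The series", "measured", "known", "first", "only" and "open" are said of these compounds alone.

In an ADME assay on HEL cells (Homo sapiens) for cytotoxicity, with a stated time of 3 days (on this read-out higher numbers stand for lower toxicity in this test and lower numbers for higher toxicity in this test), compound 1 `Cc1ccc(C#Cc2cc3cn([C@H]4C[C@H](O)[C@@H](CO)O4)c(=O)nc3o2)cc1` gives 510000 nM. Compound 2 `O=c1nc2oc(C#Cc3ccccc3)cc2cn1[C@H]1C[C@H](O)[C@@H](CO)O1` gives > 570000 nM, which is a limit of the assay and not a number. Compound 3 `O=c1nc2oc(CCc3ccccc3)cc2cn1[C@H]1C[C@H](O)[C@@H](CO)O1` carries phenethyl in place of 2-phenylethynyl on an aromatic carbon, next to the ring oxygen: phenethyl in place of 2-phenylethynyl on an aromatic carbon. For the measured compounds named here, the only measured step is a different change, hydrogen in place of methyl on an aromatic carbon, with an at least 1.1-fold higher number from compound 1 to compound 2 (0.04 log units; that floor lies within the scatter). Going by the values given here, no measured step covers this exchange, so no change beyond the scatter is expected in this assay. The estimated step is an at least 1.0-fold lower number from compound 2 to compound 3 (0.01 log units; that floor lies within the scatter). Compound 3 is expected at 550000 nM, with an estimated range of 250000 nM to 800000 nM.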

Compound 3, half-maximal cytotoxic concentration: > 560000 nM
Compound 3 ended at the assay's limit (the forecaster's own chance of this, stated with the estimate: 60%); middle value at least 1.0-fold (0.00 log units) from the limit.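

In this assay compound 3 gives > 560000 nM, which is a limit of the assay and not a number. This shows that at this position, on an aromatic carbon next to the ring oxygen, a phenethyl group without the triple bond also reaches a limit, so the triple bond is not needed for that outcome. The step between the two limits cannot be read, and the exchange of 2-(4-methylphenyl)ethynyl for phenethyl gives an at least 1.0-fold higher number from compound 1 to compound 3 (0.04 log units; that floor lies within the scatter).

Going by these compounds, how far compound 2 and compound 3 lie past their limits stays open. Also open, on these data alone, is whether an amine or a longer chain at this position would give a number instead of a limit.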